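Swapping the amide substituent on a phosphatase inhibitor

A few compounds are considered here, and "the series" means these few. Any claim that something is new, unique, unknown or untested is made for them only; others in the source may bear on it.

Measured compounds:
compound 1 `O=C(COc1ccc2cc(C(O)(C(F)(F)F)C(F)(F)F)c(O)cc2c1)Nc1nc2ccccc2s1`: 9900 nM
compound 2 `Oc1c(C(O)(C(F)(F)F)C(F)(F)F)ccc2ccccc12`: > 500000 nM

Among the measured compounds shown here, in an assay on isolated protein for inhibition of tyrosine-protein phosphatase non-receptor type 13 (Homo sapiens), read by spectrophotometry (on this read-out higher numbers stand for weaker inhibition and lower numbers for stronger inhibition), compound 1 gives 9900 nM, the only numerical value here. Compound 2, which lacks the whole side chain, reaches only a limit of the assay, > 500000 nM; this is noted as the limit of > 500000 nM in this assay, at which 1 of the 2 values shown sits. Compound 3 `CCN(CC)C(=O)COc1ccc2cc(C(O)(C(F)(F)F)C(F)(F)F)c(O)cc2c1` differs from compound 1 by diethylamino in place of (1,3-benzothiazol-2-yl)amino on a carbonyl carbon. Since the side chain separates compound 1 from the limit of compound 2, shrinking its end group is expected to cost potency, with an estimated step of a 4.0-fold higher number from compound 1 to compound 3 (0.61 log units; beyond the scatter). Compound 3 is therefore expected at 40000 nM, within 10000 nM to 200000 nM.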

Compound 3, half-maximal inhibitory concentration: > 20000 nM
Compound 3 ended at the assay's limit; the forecaster's own chance of this, stated with the estimate: 30%; the middle value lies beyond the limit too.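

In this assay compound 3 reaches only a limit of the assay (> 20000 nM) and not a number. The change from (1,3-benzothiazol-2-yl)amino to diethylamino on the carbonyl carbon can therefore be given only as a floor (an at least 2.0-fold higher number from compound 1 to compound 3 (0.30 log units; that floor lies within the scatter)), so a loss of potency is possible but not established. The new point is that keeping the side chain does not by itself yield a measured value, so the end group may matter. From the compounds shown here alone, the true value of compound 3 remains open, as does whether phenylamino or piperidine at this place would match compound 1.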